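Cyclobutyl for cyclopropyl at the clearance limit

A few compounds are considered here, and "the series" means these few. Any claim that something is new, unique, unknown or untested is made for them only; others in the source may bear on it.

In an ADME assay (liver) for metabolic stability, with Liver microsome (Rattus norvegicus) as the target, using microsomes (on this read-out lower numbers stand for slow clearance and higher numbers for fast clearance), compound 1 `CC(C)(C)CN(Cc1ccccc1C(F)(F)F)C(=O)C1CCN(S(=O)(=O)c2ccc3[nH]ncc3c2)CC1` gives > 500 mL/min/kg, which is a limit and not a number. Compound 2 `O=C(C1CCN(S(=O)(=O)c2ccc3[nH]ncc3c2)CC1)N(Cc1ccccc1C(F)(F)F)CC1CC1` gives > 500 mL/min/kg, again only a limit. Among the measured compounds shown here, the series so far therefore stands at the limit of > 500 mL/min/kg in this assay, at which 2 of the 2 values shown sit.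

Compound 3 `O=C(C1CCN(S(=O)(=O)c2ccc3[nH]ncc3c2)CC1)N(Cc1ccccc1C(F)(F)F)CC1CCC1` follows from compound 2 through cyclobutyl in place of cyclopropyl on a saturated chain carbon bound to an amide-type nitrogen, or cyclopropylmethyl to cyclobutylmethyl.

For the measured compounds named here, the one measured step at this place is a step that the two limits leave unreadable from compound 1 to compound 2, and it offers no size to carry over. Compound 3 is expected to stay in the same region of this assay because of the limit of > 500 mL/min/kg in this assay, at which 2 of the 2 values shown sit, with no step beyond the scatter foreseen and no direction readable. The expected change is a step that the limit leaves unreadable from compound 2 to compound 3. For compound 3 the estimated clearance is 600 mL/min/kg, with an expected range of 300 mL/min/kg to 1200 mL/min/kg.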

Compound 3, clearance: > 500 mL/min/kg
Compound 3: no number, only a limit; the forecaster's own chance of this, stated with the estimate: 80%; the middle value lies beyond the limit too.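

In this assay compound 3 gives > 500 mL/min/kg, a limit and not a number. Among the compounds shown here, no step among compound 1, compound 2 and compound 3 can be read, since all three values are limits. The compounds shown leave open how their actual clearances compare.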